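A few compounds are considered here, and "the series" means these few. Any claim that something is new, unique, unknown or untested is made for them only; others in the source may bear on it.

Measured so far:
Compound 1 `OC[C@@H](O[C@H]1CCCN(Cc2ncc[nH]2)[C@H]1c1ccccc1)c1cc(Cl)cc(Cl)c1` gives 47000 nM in an assay on isolated protein for activation of cGMP-dependent protein kinase 1 (Homo sapiens), read by ADP-Glo, with stated times of 30 min and 2 h, in the presence of a further agent that is not named here; a higher number here means that more compound is needed for the effect, a lower number that less compound is needed.
Compound 2 `Cc1cc(C(=O)O)ccc1CN1CCC[C@H](OC(c2cc(Cl)cc(Cl)c2)C(C)O)[C@@H]1c1ccccc1` gives 5300 nM in this assay.
Compound 3 `Cc1cc(C(=O)O)ccc1CN1CCC[C@H](OC(c2cc(Cl)cc(Cl)c2)C(C)(C)O)[C@@H]1c1ccccc1` gives 17000 nM in this assay.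

Compound 2 holds the lowest number of the three. Its nearest neighbour is compound 3, reached by a 3.2-fold higher number from compound 2 to compound 3 (0.51 log units; beyond the scatter); the change there is methyl in place of hydrogen on the saturated chain carbon bound to the ether oxygen. Compound 1 sits furthest away; it differs from compound 2 in more than one place, so its gap to compound 2 is only what the two values show.

Compound 4 `Cc1cc(C(=O)O)ccc1CN1CCC[C@H](O[C@H](CO)c2cc(F)cc(F)c2)[C@@H]1c1ccccc1` is not yet measured. It differs from compound 2 as follows: a group of 11 heavy atoms (8 carbon, 1 oxygen, 2 fluorine; one six-membered aromatic ring of carbon only) in place of a group of 12 heavy atoms (9 carbon, 1 oxygen, 2 chlorine; one six-membered aromatic ring of carbon only), on an oxygen on a saturated carbon. Two chlorine leave, two fluorine enter, and the chain carrying the hydroxyl loses a methyl, with a defined stereocentre entering. Within the data shown here, no measured step addresses the chlorine-to-fluorine exchange. Among the measured compounds shown here, the only measured step on this part of the structure, a 3.2-fold higher number from compound 2 to compound 3 (0.51 log units; beyond the scatter), shows that adding a methyl on that chain raised the number modestly; removing one runs the other way, but the aromatic ring also changes, and compound 1, which carries the same hydroxymethyl chain with a different amine cap, gives the highest number seen. On balance a moderate rise in the number is expected, so the step from compound 2 to compound 4 is estimated as a 2.3-fold higher number from compound 2 to compound 4 (0.35 log units; beyond the scatter). For compound 4 the expected value in this assay is 12000 nM, estimated to lie between 4000 nM and 40000 nM.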

Compound 4, half-maximal effective concentration: 1500 nM
For compound 4 the middle estimate is 8.0-fold (0.90 log units) above the measured one; measured number below the stated range.
By their numbers in this assay, from the lowest: compound 4; then compound 2; then compound 3; then compound 1.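

In this assay, among these compounds, the group on the oxygen on a saturated carbon proves open to change without loss: a 3.5-fold lower number from compound 2 to compound 4 (0.55 log units; beyond the scatter) is the first step at this position that lowers the number, whereas the only earlier step there, a 3.2-fold higher number from compound 2 to compound 3 (0.51 log units; beyond the scatter), raised it. The new step is a single exchange of the whole group, in which two chlorine give way to two fluorine, the chain carrying the hydroxyl loses a methyl and a defined stereocentre enters, so the size of the step cannot be divided among these three changes. No measurement at hand gives a reason for the step.

The compounds shown leave open whether the halogen exchange, the shorter chain or the defined stereocentre carries the step, and a compound changing only one of the three would separate them. Also open, on these data alone, is how the number in this assay would respond to a methoxy group in place of the hydroxyl, a longer chain carrying that hydroxyl, or a nitrile in place of the fluorine on the aromatic ring.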